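The source may hold more compounds than are shown below. What is called first, only, known or untested is meant among the compounds shown, and "the series" means these compounds.

Measured compounds:
- compound 1, `CC(=O)c1c(NNc2ccc(C)cc2)cc(C)oc1=O`: 60.1%
- compound 2, `CC(=O)c1c(NNc2ccc(Cl)cc2)cc(C)oc1=O`: 54.4%
- compound 3, `CC(=O)c1c(NNc2ccc(Br)cc2)cc(C)oc1=O`: 46.8%

In a functional assay on the whole organism for inhibition, with Rattus norvegicus as the target, read by paw edema, with a stated time of 1 h, at a dose of 50 mg/kg (a higher number here means more inhibition at the dose given (going by the name of the read-out), a lower number less inhibition), compound 1 stands highest of the three numbers. Compound 2 sits nearest to it, a number 5.7 percentage points lower from compound 1 to compound 2 (within the scatter), and compound 3 furthest, a number 13.3 percentage points lower from compound 1 to compound 3 (beyond the scatter). Between the two halogen compounds, a number 7.6 percentage points lower from compound 2 to compound 3 (within the scatter).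

Compound 4, `CC(=O)c1c(NNc2ccc([N+](=O)[O-])cc2)cc(C)oc1=O`, has not yet been measured. It differs from compound 1 in one place: nitro in place of methyl on an aromatic carbon. Going by the values given here, the steps that bear on this change are the two in which the same methyl of compound 1 was exchanged for another group at the same carbon: a number 5.7 percentage points lower from compound 1 to compound 2 (within the scatter) and a number 13.3 percentage points lower from compound 1 to compound 3 (beyond the scatter). Both went downward, one within the scatter and one modestly beyond it. Neither involves a nitro group, so the size of the present step is covered only loosely. On that footing a small downward step is expected, a number 10.1 percentage points lower from compound 1 to compound 4 (beyond the scatter), possibly no larger than the scatter. Compound 4 is therefore estimated at 50%, with a range from 35% to 65%.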

Compound 4, a percentage reported as inhibition, in the whole organism at one dose (the size of the read-out at that dose, not a potency): 53.2%
Compound 4: middle estimate off by 3.2 percentage points, on the low side, and the stated range covers the measured number.
By their numbers in this assay, from the lowest: compounds 3, 4, 2 and 1 (each within the scatter of the next, the first and the last beyond it).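

In this assay, a nitro group with its three heavy atoms and two hydrogen-bond acceptors replaces the single carbon of methyl on this aromatic carbon, para to a large group, and the step is still no larger than the scatter, with a number 6.9 percentage points lower from compound 1 to compound 4 (within the scatter). The same holds against the two halogen compounds, with a number 1.2 percentage points lower from compound 2 to compound 4 (within the scatter) and a number 6.4 percentage points higher from compound 3 to compound 4 (within the scatter), so compound 4 cannot be separated from any of the other three, even though compound 1 and compound 3 lie beyond the scatter of each other. Nothing available bears on the reason for this result.

From the compounds shown here alone, all four compounds carry a group at this one carbon, so it remains open how an amine, a carboxylic acid or a longer alkyl chain would read there. Going by these compounds, whether the same picture would hold at other doses or other times also remains open.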